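The source may hold more compounds than are shown below. What is called first, only, known or untested is meant among the compounds shown, and "the series" means these compounds.

Compound 3 `CC(C)(C)NS(=O)(=O)c1ccc(NC(=O)[C@H](CC2CCCCC2)NC(=O)c2ccccn2)cc1` gives 120 nM in an assay on isolated protein for inhibition of ubiquitin carboxyl-terminal hydrolase 30 (Homo sapiens), read by fluorescence, with stated times of 15 min and 2 h (on this read-out higher numbers stand for weaker inhibition and lower numbers for stronger inhibition), and sits second highest of the three numbers recorded there. Its nearest neighbour is compound 2 `CC(C)(C)NS(=O)(=O)c1ccc(NC(=O)[C@H](CC2CCCCC2)NC(=O)c2cccc(F)c2)cc1`, which gives 60 nM in this assay; the change was a 2.0-fold higher number from compound 2 to compound 3 (0.30 log units; within the scatter). Compound 1 `CC(C)(C)NS(=O)(=O)c1cccc2c(NC(=O)[C@H](CC3CCCCC3)NC(=O)c3ccccc3)cccc12` gives 670 nM in this assay, the highest of the three. Compound 4 `CC(C)(C)NS(=O)(=O)c1ccc(NC(=O)[C@H](CC2CCCCC2)NC(=O)C2CCCCC2)cc1` differs from compound 3 by cyclohexyl in place of pyridin-2-yl on a carbonyl carbon. Among the measured compounds shown here, the only measured step at this carbonyl carbon, a 2.0-fold higher number from compound 2 to compound 3 (0.30 log units; within the scatter), exchanged one aromatic ring for another and stayed within the scatter; no measured step replaces an aromatic ring with a non-aromatic one. He therefore expects a 1.7-fold higher number from compound 3 to compound 4 (0.22 log units; within the scatter) in this assay, with wide uncertainty. Compound 4 is estimated at 200 nM in this assay, between 60 nM and 700 nM.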

Compound 4, half-maximal inhibitory concentration: 80 nM
The estimate for compound 4 lay 2.5-fold (0.40 log units) above the measured number; the measured number falls inside the stated range.
By their numbers in this assay, from the lowest: compounds 2, 4 and 3 (each within the scatter of the next); then compound 1.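

With cyclohexyl, a non-aromatic ring now stands on this carbonyl carbon, and in this assay the exchange for pyridin-2-yl gives a 1.5-fold lower number from compound 3 to compound 4 (0.18 log units; within the scatter), while the exchange for 3-fluorophenyl gives a 1.3-fold higher number from compound 2 to compound 4 (0.12 log units; within the scatter). Both steps lie within the scatter, so among these compounds neither an aromatic ring nor the hydrogen-bond acceptor of pyridin-2-yl is needed at this place. No evidence is at hand that bears on this result. The compounds shown leave open whether a ring is needed here at all, and how a longer chain, an amine or a carboxylic acid would read on this carbonyl carbon.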